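The source may report more compounds than this note shows. Statements on the series, on what has been measured and on what is new or still open speak of the compounds shown alone.

Working notes on the series, all read in a functional assay on SK-BR-3 cells (Homo sapiens) for antiproliferative activity, read by MTT assay, with a stated time of 72 h; on this read-out higher numbers stand for weaker inhibition and lower numbers for stronger inhibition. Compound 1 (`CCN1CCN(c2cc(C)c3cc(NC(=O)c4ccc(Br)cc4)ccc3n2)CC1`) gives 6310 nM, compound 2 (`CCN1CCN(c2cc(C)c3cc(NC(=O)c4cc(Cl)cc(Cl)c4)ccc3n2)CC1`) gives 2660 nM and compound 3 (`CCN1CCN(c2cc(C)c3cc(NC(=O)c4cc5ccccc5[nH]4)ccc3n2)CC1`) gives 2550 nM. Compound 3 shares the low end of these numbers with compound 2: a 1.0-fold lower number from compound 2 to compound 3 (0.02 log units; within the scatter) stays within the scatter, while a 2.5-fold lower number from compound 1 to compound 3 (0.39 log units; beyond the scatter) lies beyond it but is modest.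

Compound 4 (`CCN1CCN(c2cc(C)c3cc(NC(=O)c4ccccc4Cl)ccc3n2)CC1`) carries 2-chlorophenyl in place of 1H-indol-2-yl on a carbonyl carbon. The remaining measured step at this place is a 2.4-fold lower number from compound 1 to compound 2 (0.38 log units; beyond the scatter), also modest. Among the measured compounds shown here, none of the measured compounds carries 2-chlorophenyl, so these steps give only a rough size. With all three numbers this close, no step beyond the scatter is expected, and any drift would most likely be toward a higher number.

The estimated change is a 1.5-fold higher number from compound 3 to compound 4 (0.17 log units; within the scatter). For compound 4 the expected value is 3800 nM, with an estimated range of 1800 nM to 8000 nM.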

Compound 4, half-maximal inhibitory concentration: > 50000 nM
Compound 4 was reported as a limit; the forecaster's own chance of this, stated with the estimate: 5%; middle value at least 13-fold (1.11 log units) from the limit.
By their numbers in this assay, from the lowest: compounds 3 and 2 (each within the scatter of the next); then compound 1. At a limit, above all of these: compound 4.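

The reading for compound 4 is a limit and not a number: the limit of > 50000 nM in this assay, at which 1 of the 4 values shown sits. The position on the carbonyl carbon is therefore less tolerant than the first three groups suggested, with 2-chlorophenyl giving an at least 19-fold higher number from compound 3 to compound 4 (1.29 log units; beyond the scatter) and an at least 18-fold higher number from compound 2 to compound 4 (1.27 log units; beyond the scatter), both large, and an at least 7.9-fold higher number from compound 1 to compound 4 (0.89 log units; beyond the scatter). Chlorine on the phenyl ring does not by itself go with this loss, as compound 2, with 3,5-dichlorophenyl, gives 2660 nM.

The compounds shown leave open whether the loss belongs to chlorine specifically or to any group placed as in 2-chlorophenyl; 2-fluorophenyl and 2-methylphenyl would bear on this. The data hold no value for unsubstituted phenyl or 4-chlorophenyl, and these two groups would show whether the loss remains without the chlorine or with the chlorine placed as in 4-chlorophenyl. Going by these compounds, the full size of each step remains unknown at this limit.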